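Adding a bromo group to compound 1

The source may report more compounds than this note shows. Statements on the series, on what has been measured and on what is new or still open speak of the compounds shown alone.

compound 1 `O=C(/C=C/c1ccccc1)c1ccc[nH]1` gives > 100000 nM (a limit)
compound 2 `O=C(/C=C/c1ccccc1Br)c1ccc[nH]1` gives 44000 nM

In a functional assay on PC-3 cells (Homo sapiens) for inhibition, read by MTT assay, with a stated time of 48 h (on this read-out lower numbers stand for stronger inhibition and higher numbers for weaker inhibition), compound 1 gives > 100000 nM as a limit of the assay and not a number. Compound 3 `O=C(/C=C/c1ccc(Br)cc1)c1ccc[nH]1` differs from compound 1 by one change bromo in place of hydrogen on an aromatic carbon that puts bromo in place of hydrogen on an aromatic carbon, para to a group of 9 heavy atoms. Going by the values given here, one measured step bears on this: an at least 2.2-fold lower number from compound 1 to compound 2 (0.35 log units; beyond the scatter) for the same kind of swap made at a different place on the ring. After that swap, compound 2 gives 44000 nM in this assay as a true number. From the compounds shown here alone, this single step starts from a limit, so its real size stays open, and one example cannot show how much the place of the bromo matters. A modest move toward a lower number, meaning stronger inhibition, is therefore expected again, although compound 3 could also stay at the limit of the assay. The step expected is an at least 2.2-fold lower number from compound 1 to compound 3 (0.34 log units; beyond the scatter) in the direction of stronger inhibition. Compound 3 is estimated at 45000 nM with an expected range from 15000 nM to 100000 nM for a measured number.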

Compound 3, half-maximal inhibitory concentration: 44000 nM
Compound 3: middle estimate off by 1.0-fold (0.01 log units), on the high side; the range from low to high includes it.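

In this assay, bromo in place of hydrogen on an aromatic carbon, para to a group of 9 heavy atoms, gives an at least 2.2-fold lower number from compound 1 to compound 3 (0.35 log units; beyond the scatter), which points toward stronger inhibition. The move to a measurable number is therefore not tied to the single ring place seen before, since compound 2 gives 44000 nM and compound 3 gives 44000 nM, the same printed value at two different places on the ring. The full size of this step cannot be read, because compound 1 stands at a limit of the assay and not at a true number: the limit of > 100000 nM in this assay, at which 1 of the 3 values shown sits.

Going by these compounds alone, with bromo as the only group added to the ring, it remains open whether a chloro group, a methoxy group or an amine at this place would give a similar number, a lower one or a return to the limit. From the compounds shown here alone, it also remains open whether a longer chain between the two rings of the shared core would change the number in this assay further.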